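Cyclopropylmethoxy in place of ethoxy on the acid core

The source may report more compounds than this note shows. Statements on the series, on what has been measured and on what is new or still open speak of the compounds shown alone.

Two compounds of the series have numbers in an ADME assay on the whole organism (strain Han-Wistar) for pharmacokinetics, with Rattus norvegicus as the target, read by LC-MS, at a dose of 1 mg/kg by the intravenous route; on this read-out higher numbers stand for wider distribution into tissues and lower numbers for narrower distribution. Compound 1 `CCOc1cc2oc(=O)n(CCC(=O)O)c2cc1Cl` gives 0.36 L/kg in this assay. Compound 2 `Cc1ccc([C@@H](C)Oc2cc3onc(CCC(=O)O)c3cc2Cl)nn1`, which carries a different core and a different side chain on the aromatic oxygen, gives 1.1 L/kg in this assay. Of the two numbers, compound 1 stands at the lower one, and the gap to compound 2 lies beyond the usual scatter; since the two structures differ in more than one place, no single change can be read from that gap.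

Compound 3 `O=C(O)CCn1c(=O)oc2cc(OCC3CC3)c(Cl)cc21` has not yet been measured in this assay. It differs from compound 1 by cyclopropyl in place of methyl on a saturated chain carbon bound to an oxygen on an aromatic ring. Among the measured compounds shown here, no measured pair shows the effect of this change on its own, so the expectation rests on compound 1 alone. A small step is expected from compound 1 to compound 3, a 1.4-fold higher number from compound 1 to compound 3 (0.14 log units; within the scatter), upward if anything, and likely within the scatter of repeated measurements. Compound 3 is therefore estimated at 0.5 L/kg in this assay, with a range from 0.3 L/kg to 0.9 L/kg.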

Compound 3, volume of distribution at steady state: 0.26 L/kg
Compound 3: the middle estimate sits 1.9-fold (0.28 log units) above what was measured; measured number below the stated range.
By their numbers in this assay, from the lowest: compounds 3 and 1 (each within the scatter of the next); then compound 2.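

The series now has its first pair differing in one place: cyclopropyl in place of methyl on a saturated chain carbon bound to an oxygen on an aromatic ring, which reads as ethoxy to cyclopropylmethoxy, gives a 1.4-fold lower number from compound 1 to compound 3 (0.14 log units; within the scatter) in this assay on the shared core. At this position, then, a group of 3 heavy atoms with a three-membered ring takes the place of a group of 1 heavy atom, and compound 1 and compound 3 cannot be told apart on this read-out. Nothing measured here bears on why the step has this size.

On these data alone, whether a longer chain, an amine or a hydroxyl at this same place would give a step beyond the scatter remains open, as does whether the cyclopropyl change gives a similar step on another core, such as that of compound 2. No pair shown changes the core or the side chain on the aromatic oxygen alone, so the separate contribution of each to the number for compound 2 also remains open.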